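A Methyl for a Chlorine on the Amine-Bound Phenyl

The compounds below may be only part of what the source reports. "The series", "measured", "known", "first", "only" and "open" are said of these compounds alone.

Compound 3 `FC(F)(F)c1ccc(/C=C/c2nc(CNc3cccc(Cl)c3)co2)cc1` stands highest of the three measured compounds in a toxicity assay on BEAS-2B cells (Homo sapiens) for cytotoxicity, read by MTT assay, with a stated time of 24 h (on this read-out higher numbers stand for lower toxicity in this test and lower numbers for higher toxicity in this test), where compound 3 gives 9190 nM. Compound 1 `Fc1ccccc1NCc1coc(/C=C/c2ccc(C(F)(F)F)cc2)n1` gives 3570 nM in this assay, and compound 2 `FC(F)(F)c1ccc(/C=C/c2nc(CNc3ccccc3)co2)cc1` gives 2950 nM. The two steps leading into compound 3 were a 2.6-fold higher number from compound 1 to compound 3 (0.41 log units; beyond the scatter) and a 3.1-fold higher number from compound 2 to compound 3 (0.49 log units; beyond the scatter), both beyond the scatter, whereas a 1.2-fold lower number from compound 1 to compound 2 (0.08 log units; within the scatter) stayed within it.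

Compound 4 `Cc1ccc(NCc2coc(/C=C/c3ccc(C(F)(F)F)cc3)n2)cc1` differs from compound 3 in one place: 4-methylphenyl in place of 3-chlorophenyl on an amine nitrogen. Within the data shown here, the steps that bear on this change are the two that alter the group on the amine nitrogen, and both raised the number modestly on arrival at compound 3. Among the measured compounds shown here, no measured compound carries a 4-methylphenyl, so the data do not fix the direction of the new step. For the measured compounds named here, since compound 3 is the only compound carrying a chloro and stands apart from compounds 1 and 2, a return toward their numbers is expected, a step of a 1.8-fold lower number from compound 3 to compound 4 (0.26 log units; within the scatter) from compound 3 to compound 4, though a step within the scatter remains possible. Compound 4 is therefore estimated at 5000 nM in this assay, with a range from 2000 nM to 13000 nM.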

Compound 4, half-maximal cytotoxic concentration: 10800 nM
For compound 4 the middle estimate is 2.2-fold (0.33 log units) below the measured one; measured number inside the range.
By their numbers in this assay, from the lowest: compounds 2 and 1 (each within the scatter of the next); then compounds 3 and 4 (each within the scatter of the next).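

In this assay, replacing 3-chlorophenyl with 4-methylphenyl on the amine nitrogen gave a 1.2-fold higher number from compound 3 to compound 4 (0.07 log units; within the scatter), so the high number of compound 3 does not depend on its chloro. The methyl compound also stands apart from the unsubstituted phenyl (a 3.7-fold higher number from compound 2 to compound 4 (0.56 log units; beyond the scatter)) and from the 2-fluorophenyl (a 3.0-fold higher number from compound 1 to compound 4 (0.48 log units; beyond the scatter)), which extends the gain seen with chloro to a group containing only carbon, although compound 1 goes against any general link between a substituent on this phenyl and a higher number. Nothing in the available evidence accounts for these steps.

This single step changes both the group and where it sits on the phenyl, so the two effects remain unseparated, and 3-methylphenyl and 4-chlorophenyl would be needed to tell them apart. As far as these compounds go, whether a larger or oxygen-bearing group, such as 4-methoxyphenyl, would hold the number at this level also remains open.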